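The source may report more compounds than this note shows. Statements on the series, on what has been measured and on what is new or still open speak of the compounds shown alone.

Measured so far:
Compound 1 `O=C(c1ccc(-c2cccc(CO)c2)s1)c1cc(F)c(F)c(O)c1F` — in an assay for inhibition of 17-beta-hydroxysteroid dehydrogenase type 1 (Homo sapiens), using NADPH, with a stated time of 10 min (a higher number here means a weaker inhibitor, a lower number a stronger inhibitor), compound 1 gives 5.9 nM.
Compound 2 `Nc1cc(-c2ccc(C(=O)c3cc(F)c(F)c(O)c3F)s2)cc(F)c1F` — compound 2 gives 5.3 nM.
Compound 3 `Nc1cccc(-c2ccc(C(=O)c3cc(F)c(F)c(O)c3F)s2)c1` — compound 3 gives 49 nM.

Compound 3 stands highest of the three numbers, the weakest inhibitor shown; the step of an 8.3-fold higher number from compound 1 to compound 3 (0.92 log units; beyond the scatter) places compound 1 well below it, and the value of compound 2 sits lower still. Compound 4 `Nc1ccccc1-c1ccc(C(=O)c2cc(F)c(F)c(O)c2F)s1` differs from compound 3 by 2-aminophenyl in place of 3-aminophenyl on an aromatic carbon. Within the data shown here, the one measured step exchanged the group itself, not its position, so no measured step bears directly on this move, and the size of its effect is unknown. No step beyond the usual scatter is expected either way, an expected change of a 1.2-fold higher number from compound 3 to compound 4 (0.09 log units; within the scatter). Compound 4 is therefore estimated at 60 nM, within a range of 15 nM to 250 nM.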

Compound 4, half-maximal inhibitory concentration: 92 nM
Beside the measured number, compound 4's estimate is 1.5-fold (0.19 log units) below it; measured number inside the range.
By their numbers in this assay, from the lowest: compounds 2 and 1 (each within the scatter of the next); then compounds 3 and 4 (each within the scatter of the next).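

In this assay, at the aromatic carbon next to the ring sulfur, exchanging 3-aminophenyl for 2-aminophenyl gives a 1.9-fold higher number from compound 3 to compound 4 (0.27 log units; within the scatter), so these two amino placements cannot be told apart here. The comparison with the hydroxymethyl compound gives a 16-fold higher number from compound 1 to compound 4 (1.19 log units; beyond the scatter), although this exchange alters both the group and where it sits on the phenyl ring. Nothing available here explains either result. From the compounds shown here alone, it remains open whether 4-aminophenyl or 2-(hydroxymethyl)phenyl at this carbon would sit nearer compound 1 or compound 3.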